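Swapping the aryl group on the acrylic acid arm

The source may hold more compounds than are shown below. What is called first, only, known or untested is meant among the compounds shown, and "the series" means these compounds.

Two compounds share one core, an indole bearing an acetyl group and a benzyloxy group, carrying an acrylic acid chain with an aryl group on the chain carbon bound to the carbonyl carbon. Compound 1 has the structure `COc1cccc(/C(=C\c2cn(C(C)=O)c3ccc(OCc4ccccc4)cc23)C(=O)O)c1`. In a functional assay on M14 cells (Homo sapiens) for cytotoxicity, read by MTT assay, with a stated time of 72 h (on this read-out lower numbers stand for stronger inhibition and higher numbers for weaker inhibition), compound 1 gives > 100000 nM, which is a limit of the assay rather than a number. Compound 2 has the structure `CC(=O)n1cc(/C=C(/C(=O)O)c2ccc(Cl)cc2)c2cc(OCc3ccccc3)ccc21`. In this assay compound 2 gives > 100000 nM, again a limit. The step from compound 1 to compound 2 is therefore a step that the two limits leave unreadable from compound 1 to compound 2; its size is hidden because both values sit at the limit of > 100000 nM in this assay, at which 2 of the 2 values shown sit.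

Compound 3, with the structure `COc1cc(OC)cc(/C(=C\c2cn(C(C)=O)c3ccc(OCc4ccccc4)cc23)C(=O)O)c1`, is still to be measured. It differs from compound 2 by 3,5-dimethoxyphenyl in place of 4-chlorophenyl on a double-bonded chain carbon bound to a carbonyl carbon and a double-bonded chain carbon. Among the compounds with values here, the only step on record is unreadable, so no direction can be taken from it, and compound 3 is expected to sit close to the same limit. The estimate for compound 3 in this assay is 150000 nM, with a range from 30000 nM to 1000000 nM. The expected step from compound 2 to compound 3 is a step that the limit leaves unreadable from compound 2 to compound 3.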

Compound 3, half-maximal inhibitory concentration: 94000 nM
The estimate for compound 3 lay 1.6-fold (0.20 log units) above the measured number, within the range that was stated.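

In this assay, within the data shown here, compound 3 gives 94000 nM, the first value in this small set that is a real number and not a limit. With 3,5-dimethoxyphenyl on the double-bonded chain carbon bound to a carbonyl carbon, the steps can now be read in part, as an at least 1.0-fold lower number from compound 2 to compound 3 (0.02 log units; that floor lies within the scatter) and as an at least 1.0-fold lower number from compound 1 to compound 3 (0.02 log units; that floor lies within the scatter), the latter being methoxy in place of hydrogen on an aromatic carbon. Both steps give only a floor, so their true sizes stay hidden and neither shows a clear gain in strength from the added methoxy or from the swap of the aryl group: the limit of > 100000 nM in this assay, at which 2 of the 3 values shown sit.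

The compounds shown leave open whether any group on this chain carbon can bring the number far down, for example an aminophenyl group, which would put an amine where these three compounds carry only chloro or methoxy substituents. They also leave open how the series would respond to a change elsewhere, such as a methyl ester or a primary amide in place of the carboxylic acid.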